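This account rests on a few compounds, and the source may have more. Where it says the series, first, only, none or still open, it means among the compounds named here.

Going by the values given here, compound 3 `CC(C)(C)CNC(=O)C[C@H](NC(=O)c1ccc(C(C)(C)C)cc1)C(=O)N[C@@H](CCc1ccccc1)C(=O)NCc1ccccc1` gives 32 nM in an assay on HEK293 cells for inhibition of nuclear factor NF-kappa-B complex (Homo sapiens), read by a luciferase reporter, with stated times of 1 h and 3 h (a higher number here means a weaker inhibitor, a lower number a stronger inhibitor), the second highest of the three numbers measured so far. Compound 1 `CC(C)(C)CNC(=O)C[C@H](NC(=O)C(C)(C)C)C(=O)N[C@@H](CCc1ccccc1)C(=O)NCc1ccccc1` gives 62 nM, and the step of a 1.9-fold lower number from compound 1 to compound 3 (0.29 log units; within the scatter) stays within the scatter. Compound 2 `CC(C)(C)CNC(=O)C[C@H](NC(=O)CCc1ccccc1)C(=O)N[C@@H](CCc1ccccc1)C(=O)NCc1ccccc1` gives 12 nM, and the step of a 2.7-fold higher number from compound 2 to compound 3 (0.43 log units; beyond the scatter) lies beyond it. Compound 4 `CC(C)(C)CNC(=O)C[C@H](NC(=O)c1ccc(OCc2ccccc2)cc1)C(=O)N[C@@H](CCc1ccccc1)C(=O)NCc1ccccc1` differs from compound 3 by benzyloxy in place of tert-butyl on an aromatic carbon. Among the compounds with values here, no measured step alters a substituent on this ring; the nearest comparisons vary the group on the carbonyl carbon, where a 5.2-fold lower number from compound 1 to compound 2 (0.71 log units; beyond the scatter) shows that a group bearing a phenyl gave a lower number, while a 1.9-fold lower number from compound 1 to compound 3 (0.29 log units; within the scatter) gave no change beyond the scatter. A small decrease in this assay is therefore expected, amounting to the step of a 1.6-fold lower number from compound 3 to compound 4 (0.20 log units; within the scatter). Compound 4 is estimated at 20 nM, with a range from 7 nM to 60 nM.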

Compound 4, half-maximal inhibitory concentration: 22 nM
Beside the measured number, compound 4's estimate is 1.1-fold (0.04 log units) below it; the range from low to high includes it.
By their numbers in this assay, from the lowest: compounds 2, 4, 3 and 1 (each within the scatter of the next, the first and the last beyond it).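

The first change shown on this ring, benzyloxy in place of tert-butyl on an aromatic carbon, gives in this assay a 1.5-fold lower number from compound 3 to compound 4 (0.16 log units; within the scatter). This position therefore accepts benzyloxy, which brings a six-membered aromatic ring and a hydrogen-bond acceptor, with no change beyond the scatter. No measured evidence bears on this result.
The compounds shown leave open how a hydroxyl, an amine or a carboxylic acid on this aromatic carbon would read, and whether a longer chain ending in phenyl would differ from benzyloxy there.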